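Swapping thiophen-2-yl for 4-ethylphenyl on the sulfonyl sulfur

The source may report more compounds than this note shows. Statements on the series, on what has been measured and on what is new or still open speak of the compounds shown alone.

In an ADME assay on HEK293 cells (Homo sapiens) for cytotoxicity, read by resazurin assay, with a stated time of 48 h (on this read-out higher numbers stand for lower toxicity in this test and lower numbers for higher toxicity in this test), compound 1 (`Cc1ccc(S(=O)(=O)Nc2ccc(-c3nc4ccccc4o3)cc2)cc1`) gives 88000 nM. Compound 2 (`O=S(=O)(Nc1ccc(-c2nc3ccccc3o2)cc1)c1ccccc1F`) reads > 100000 nM, which is a limit of the assay. Compound 3 (`O=S(=O)(Nc1ccc(-c2nc3ccccc3o2)cc1)c1cccs1`) reads > 100000 nM, which is also a limit and not a number. Compound 3 thus stands at the limit of > 100000 nM in this assay, at which 2 of the 3 values shown sit.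

Compound 4 (`CCc1ccc(S(=O)(=O)Nc2ccc(-c3nc4ccccc4o3)cc2)cc1`) changes one place of compound 3: 4-ethylphenyl in place of thiophen-2-yl on a sulfonyl sulfur. It has 4-ethylphenyl in place of thiophen-2-yl on a sulfonyl sulfur. The nearest measured change runs the opposite way, between 4-methylphenyl and thiophen-2-yl: an at least 1.1-fold higher number from compound 1 to compound 3 (0.05 log units; that floor lies within the scatter). The other measured change from compound 1 is similar: an at least 1.1-fold higher number from compound 1 to compound 2 (0.05 log units; that floor lies within the scatter). Neither floor shows a change beyond the scatter, and a step that the two limits leave unreadable from compound 2 to compound 3 adds nothing. For the measured compounds named here, compound 1, at 88000 nM, is the only measured compound with a number, and it carries a 4-substituted phenyl. In this assay, a small move toward a lower number, hardly beyond the scatter, is therefore expected: an at least 1.2-fold lower number from compound 3 to compound 4 (0.09 log units; that floor lies within the scatter). The estimate for compound 4 is 80000 nM, expected to fall between 40000 nM and 160000 nM.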

Compound 4, half-maximal cytotoxic concentration: 82000 nM
Estimate against measurement, compound 4: 1.0-fold (0.01 log units) below; low and high end bracket the measured number.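

Compound 4 adds a second measured number in this assay, and lengthening the 4-substituted phenyl group from methyl to ethyl leaves the reading within the scatter: a 1.1-fold lower number from compound 1 to compound 4 (0.03 log units; within the scatter). Against the other two groups on the sulfonyl sulfur, the steps are an at least 1.2-fold lower number from compound 3 to compound 4 (0.08 log units; that floor lies within the scatter) and an at least 1.2-fold lower number from compound 2 to compound 4 (0.08 log units; that floor lies within the scatter), so neither floor shows 4-ethylphenyl differing from thiophen-2-yl or 2-fluorophenyl beyond the scatter. On these data alone, the values of compound 2 and compound 3 remain limits of the assay and not numbers, so the true size of these two steps stays unknown: the limit of > 100000 nM in this assay, at which 2 of the 4 values shown sit.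

As far as these compounds go, it remains open whether any group at this place can move the reading beyond the scatter. An amine, a carboxylic acid or a longer chain on the phenyl ring in place of the ethyl group would test this.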